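The compounds below may be only part of what the source reports. "The series", "measured", "known", "first", "only" and "open" are said of these compounds alone.

Compound 1 `CCN1CCN(c2nc(Nc3ccc(C#N)c(C(F)(F)F)c3)nc(Oc3ccnc4ccccc34)n2)CC1` gives 86600 nM in a functional assay on DU-145 cells (Homo sapiens) for cytotoxicity, read by sulforhodamine B assay, with a stated time of 48 h; a lower number here means a stronger inhibitor of growth, a higher number a weaker inhibitor of growth. Compound 2 `N#Cc1ccc(Nc2nc(Oc3ccnc4ccccc34)nc(N3CCN(c4ccccc4F)CC3)n2)cc1C(F)(F)F` reaches only the limit of this assay, > 100000 nM, so its standing is known only as a bound. For the measured compounds named here, the one measured step, an at least 1.1-fold higher number from compound 1 to compound 2 (0.06 log units; that floor lies within the scatter), is thus also only a bound. Compound 3 `N#Cc1ccc(Nc2nc(Oc3ccnc4ccccc34)nc(N3CCN(c4cccc(Cl)c4Cl)CC3)n2)cc1C(F)(F)F` differs from compound 2 by 2,3-dichlorophenyl in place of 2-fluorophenyl on an amine nitrogen in a ring. Going by the values given here, with only one bounded step to draw on, she expects a step that the limit leaves unreadable from compound 2 to compound 3, no movement beyond the scatter. Her estimate for compound 3 is 150000 nM, in a range from 60000 nM to 400000 nM, most likely again reported only as a limit of this assay.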

Compound 3, concentration for 50% growth inhibition: > 100000 nM
Compound 3: no number, only a limit; the forecaster's own chance of this, stated with the estimate: 70%; the middle value lies beyond the limit too.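

In this assay, compound 3 also sits at a limit rather than a number, so 2,3-dichlorophenyl on the ring amine nitrogen joins 2-fluorophenyl there. Replacing ethyl with 2,3-dichlorophenyl gives an at least 1.1-fold higher number from compound 1 to compound 3 (0.06 log units; that floor lies within the scatter), again only a bound. The step between the two phenyl compounds cannot be read, and only the ethyl compound keeps a number: the limit of > 100000 nM in this assay, at which 2 of the 3 values shown sit.

From the compounds shown here alone, whether a plain phenyl, a benzyl or a longer chain on that nitrogen would give a number within the range of this assay stays open. So does the true size of any change at this position.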